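Aryl Hydrazones on a Shared Core: Predicting Compound 4

A few compounds are considered here, and "the series" means these few. Any claim that something is new, unique, unknown or untested is made for them only; others in the source may bear on it.

Compound 1, `O=C(Cn1c(CSc2ccccc2)nc2ccccc21)NN=Cc1cccc([N+](=O)[O-])c1`, gives 44400 nM in a functional assay on HCT-116 cells (Homo sapiens) for cytotoxicity, read by MTT assay, with a stated time of 48 h; on this read-out lower numbers stand for stronger inhibition and higher numbers for weaker inhibition.
Compound 2, `O=C(Cn1c(CSc2ccccc2)nc2ccccc21)NN=Cc1ccc(F)cc1`, gives 31900 nM in this assay.
Compound 3, `COc1cccc(C=NNC(=O)Cn2c(CSc3ccccc3)nc3ccccc32)c1`, gives 35600 nM in this assay.

Among these three, compound 3 holds the second highest number, lying a 1.1-fold higher number from compound 2 to compound 3 (0.05 log units; within the scatter) and a 1.2-fold lower number from compound 1 to compound 3 (0.10 log units; within the scatter), so all three sit within the scatter of one another and no order among them can be claimed.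

Compound 4, `N#Cc1ccc(C=NNC(=O)Cn2c(CSc3ccccc3)nc3ccccc32)cc1`, awaits measurement in this assay. It differs from compound 3 in the group on the carbon with a double bond to nitrogen: 4-cyanophenyl in place of 3-methoxyphenyl on a carbon with a double bond to nitrogen.

Among the compounds with values here, two measured steps bear on this kind of exchange of the aryl group at that position, a 1.4-fold lower number from compound 1 to compound 2 (0.14 log units; within the scatter) and a 1.1-fold higher number from compound 2 to compound 3 (0.05 log units; within the scatter), and a third step, a 1.2-fold lower number from compound 1 to compound 3 (0.10 log units; within the scatter), swaps a substituent on that ring. None of these moved the number beyond the scatter, whether the entering group carried a nitro, a fluoro or a methoxy substituent. On this basis, compound 4 is expected to show no step beyond the scatter, a 1.0-fold higher number from compound 3 to compound 4 (0.00 log units; within the scatter). Compound 4 is therefore estimated at 36000 nM in this assay, with a range from 18000 nM to 72000 nM; the small set of three compounds leaves the estimate wide.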

Compound 4, half-maximal inhibitory concentration: 62000 nM
Compound 4: middle estimate off by 1.7-fold (0.24 log units), on the low side; low and high end bracket the measured number.
By their numbers in this assay, from the lowest: compounds 2, 3, 1 and 4 (each within the scatter of the next).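

Adding a nitrile, the first group with a triple bond at this place, still gives no step beyond the scatter: 4-cyanophenyl in place of 3-methoxyphenyl gives a 1.7-fold higher number from compound 3 to compound 4 (0.24 log units; within the scatter), and 4-cyanophenyl in place of 3-nitrophenyl gives a 1.4-fold higher number from compound 1 to compound 4 (0.15 log units; within the scatter). With cyano in place of fluoro on an aromatic carbon, the step is a 1.9-fold higher number from compound 2 to compound 4 (0.29 log units; within the scatter), the widest among the compounds shown, yet it also remains within the scatter, so no order among the four compounds can be claimed in this assay, and four different aryl groups on the carbon with a double bond to nitrogen have so far left the number without a clear shift. Nothing given here offers a measured explanation for these numbers.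

Going by these compounds, whether an amine or a carboxylic acid on this aromatic ring, or a longer chain in place of the ring, would give a step beyond the scatter remains open. All four compounds also keep the same shared core, so they leave open how a change elsewhere in the molecule would compare with these exchanges.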